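Tetrafluorophenyl substitution pattern and passive permeability

This account rests on a few compounds, and the source may have more. Where it says the series, first, only, none or still open, it means among the compounds named here.

Among the compounds with values here, compound 1 `Cc1c(CCCC(=O)O)c2cccc(/C=C/c3ccc(OCCCCc4ccccc4)cc3)c2n1CC(=O)O` sits at the lower end of the two numbers so far: in a physicochemical assay for permeability, using PAMPA, with a stated time of 4 h, at pH 6.2, tested at 50 uM (on this read-out lower numbers stand for lower permeability and higher numbers for higher permeability), compound 1 gives 1.3 10^-6 cm/s, while compound 2 `Cc1c(CCCC(=O)O)c2cccc(/C=C/c3ccc(OCCCCc4c(F)c(F)cc(F)c4F)cc3)c2n1CC(=O)O` gives 9.4 10^-6 cm/s. Within the data shown here, the only measured step is a 7.2-fold higher number from compound 1 to compound 2 (0.86 log units; beyond the scatter). Compound 3 `Cc1c(CCCC(=O)O)c2cccc(/C=C/c3ccc(OCCCCc4c(F)cc(F)c(F)c4F)cc3)c2n1CC(=O)O` is unmeasured; its change from compound 1 is 2,3,4,6-tetrafluorophenyl in place of phenyl on a saturated chain carbon, four bonds along the chain from an oxygen on an aromatic ring, the same kind of exchange as in the measured step but with a different fluorine arrangement. That step bears directly on the expectation, and a rise of similar size, beyond the scatter, is expected, a 5.4-fold higher number from compound 1 to compound 3 (0.73 log units; beyond the scatter). For compound 3 the estimate in this assay is 7 10^-6 cm/s, with a range from 3 10^-6 cm/s to 16 10^-6 cm/s.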

Compound 3, apparent permeability: 2.9 10^-6 cm/s
Beside the measured number, compound 3's estimate is 2.4-fold (0.38 log units) above it; the whole stated range lies above it.
By their numbers in this assay, from the lowest: compound 1; then compound 3; then compound 2.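

The exchange of phenyl for a tetrafluorophenyl group at this position does not give one fixed result: in this assay the 2,3,4,6-tetrafluorophenyl exchange gives a 2.2-fold higher number from compound 1 to compound 3 (0.35 log units; beyond the scatter). The fluorine arrangement alone, with the fluorine count unchanged, gives a 3.2-fold lower number from compound 2 to compound 3 (0.51 log units; beyond the scatter). Both tetrafluorophenyl compounds still read above the phenyl compound, but the arrangement matters at this position as well as the presence of fluorine.

No supporting data account for the gap between the two arrangements. As far as these compounds go, whether a pentafluorophenyl or a pyridyl group at this position would read nearer compound 2 or compound 3 remains open.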